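This account rests on a few compounds, and the source may have more. Where it says the series, first, only, none or still open, it means among the compounds named here.

Measured compounds:
Compound 1, `CS(=O)(=O)c1ccc(-c2cnc3[nH]cc(-c4nnc(-c5ccccc5)o4)c(=O)c3c2)cc1`, gives 5.2% in a functional assay on KB cells (Homo sapiens) for inhibition, read by MTT assay, with a stated time of 24 h, tested at 10 uM; a lower number here means less inhibition of growth, a higher number more inhibition of growth at the concentration tested.
Compound 2, `CS(=O)(=O)c1ccc(-c2cnc3[nH]cc(-c4nnc(-c5ccc(Cl)cc5)o4)c(=O)c3c2)cc1`, gives 9.3% in this assay.

Going by the values given here, compound 2 stands highest of the two numbers in this assay, but its only neighbour is compound 1, and the step of a number 4.1 percentage points higher from compound 1 to compound 2 (within the scatter) lies within the scatter, so the two compounds cannot be told apart on these data. The unmeasured compound 3, `Cc1cccc(-c2nnc(-c3c[nH]c4ncc(-c5ccc(S(C)(=O)=O)cc5)cc4c3=O)o2)c1`, differs from compound 2 in one place: 3-methylphenyl in place of 4-chlorophenyl on an aromatic carbon. Among the compounds with values here, only one measured step bears on this change, a number 4.1 percentage points higher from compound 1 to compound 2 (within the scatter), in which chloro replaced hydrogen on the phenyl group and the read-out stayed within the scatter. Within the data shown here, no measured step concerns a methyl group, so the expectation rests on the observation that both measured compounds sit near the bottom of the scale in this assay. Compound 3 is accordingly expected to show a number 1.3 percentage points lower from compound 2 to compound 3 (within the scatter), which is no step beyond the scatter. The estimate for compound 3 is 8%, with an expected range from 0% to 20%.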

Compound 3, percent growth inhibition at one concentration: 7.5%
Compound 3: middle estimate off by 0.5 percentage points, on the high side; the measured number falls inside the stated range.
By their numbers in this assay, from the lowest: compounds 1, 3 and 2 (each within the scatter of the next).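

In this assay, the step to the 3-methylphenyl group (a number 1.8 percentage points lower from compound 2 to compound 3 (within the scatter)) and the step that puts methyl in place of hydrogen on the phenyl group (a number 2.3 percentage points higher from compound 1 to compound 3 (within the scatter)) both stay within the scatter. The earlier compounds shown here showed this only for a chloro group, so the phenyl group on the five-membered aromatic ring now accepts two different substituents, in the 3-methylphenyl and 4-chlorophenyl groups, with no change that can be read, and compound 1, compound 2 and compound 3 cannot be told apart at the concentration tested. Nothing measured here accounts for these numbers or for the low level at which all three compounds sit.

Going by these compounds, whether an amine, a carboxylic acid or a longer chain on this phenyl group would carry the number beyond the scatter remains open. On these data alone, it is also open whether any change elsewhere on the shared core would do so, since the three compounds differ only in this one substituent.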